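This account rests on a few compounds, and the source may have more. Where it says the series, first, only, none or still open, it means among the compounds named here.

Compound 3 `CC1=C(C(=O)OC(C)C)C(c2cccs2)N/C(=N/C#N)N1` gives 349 nM in an assay on HEK293 cells for displacement of a labelled ligand from adenosine receptor A2b (Homo sapiens), with a stated time of 30 min (on this read-out higher numbers stand for weaker inhibition and lower numbers for stronger inhibition), and stands at the highest of the three numbers obtained so far. Compound 1 `CC1=C(C(=O)OC(C)C)C(c2ccco2)N/C(=N/C#N)N1` gives 24.3 nM in this assay, and compound 2 `CCOC(=O)C1=C(C)N/C(=N\C#N)NC1c1ccoc1` gives 102 nM. Against compound 1, compound 3 is separated by a 14-fold higher number from compound 1 to compound 3 (1.16 log units; beyond the scatter). Against compound 2 no single-point step can be drawn, since the two structures differ at the ester as well as at the aryl group; their values simply stand as they are.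

Compound 4 `CC1=C(C(=O)OC(C)C)C(c2ccoc2)N/C(=N/C#N)N1` is still to be measured. It differs from compound 3 in that (furan-3-yl in place of thiophen-2-yl on a saturated ring carbon). Among the compounds with values here, one measured step bears on this change: a 14-fold higher number from compound 1 to compound 3 (1.16 log units; beyond the scatter), in which a furan replaced the thiophene and the number fell markedly. That step concerns a furan-2-yl rather than the furan-3-yl entering here, so it transfers only in part. Compound 2 also carries a furan-3-yl and gives 102 nM, which points in the same direction without being a clean comparison. On this basis compound 4 is expected to move to a lower number than compound 3, by about a 5.8-fold lower number from compound 3 to compound 4 (0.76 log units; beyond the scatter). Compound 4 is therefore estimated at 60 nM, with a range from 20 nM to 200 nM.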

Compound 4, inhibition constant: 59.4 nM
Compound 4: the middle estimate sits 1.0-fold (0.00 log units) above what was measured; the range from low to high includes it.
By their numbers in this assay, from the lowest: compound 1; then compounds 4 and 2 (each within the scatter of the next); then compound 3.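

In this assay, replacing thiophen-2-yl with furan-3-yl on the saturated ring carbon also lowers the number (a 5.9-fold lower number from compound 3 to compound 4 (0.77 log units; beyond the scatter)), so among the compounds shown the lower number is not confined to the furan-2-yl of compound 1. The two furans can still be told apart at this position. Moving from furan-2-yl to furan-3-yl gives a modest step beyond the scatter (a 2.4-fold higher number from compound 1 to compound 4 (0.39 log units; beyond the scatter)), with the isopropoxycarbonyl group in place in both compounds. With furan-3-yl held constant, the added methyl on the ester chain stays within the scatter (a 1.7-fold lower number from compound 2 to compound 4 (0.23 log units; within the scatter)), so the ethyl and isopropyl esters cannot be separated in this assay, and the earlier gap between these two furan-3-yl compounds gives no reading of an ester effect.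

Open, on these data alone, is how a phenyl or a pyridine ring on this saturated ring carbon would compare with the furans, and whether a longer chain on the ester would remain within the scatter of these two esters. No measurement at hand accounts for any of these differences.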